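This account rests on a few compounds, and the source may have more. Where it says the series, first, only, none or still open, it means among the compounds named here.

Measured compounds:
- compound 1 `O=C(CN1CCN(c2nnc(Cc3ccncc3)c3ccccc23)CC1)Nc1ccc(F)c(F)c1`, a functional assay on HT-29 cells (Homo sapiens) for cytotoxicity, read by MTT assay, with a stated time of 72 h; a higher number here means a weaker inhibitor, a lower number a stronger inhibitor: 2320 nM
- compound 2 `O=C(CN1CCN(c2nnc(Cc3ccncc3)c3ccccc23)CC1)Nc1ccc(F)c(Cl)c1`, this assay: 880 nM
- compound 3 `Cc1ccc(F)cc1NC(=O)CN1CCN(c2nnc(Cc3ccccc3)c3ccccc23)CC1`, this assay: 171000 nM

Among the measured compounds shown here, compound 3 stands at the highest of the three numbers in this assay, far from compound 1 and still further from compound 2; it also carries a different core from those two, so no single step links it to either.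

Compound 4 `Cc1ccc(NC(=O)CN2CCN(c3nnc(Cc4ccccc4)c4ccccc34)CC2)c(C)c1` has not yet been measured in this assay. It differs from compound 3 in one place: 2,4-dimethylphenyl in place of 5-fluoro-2-methylphenyl on an amide-type nitrogen.

For the measured compounds named here, only one measured step exists, a 2.6-fold lower number from compound 1 to compound 2 (0.42 log units; beyond the scatter), and it concerns a halogen swap on a different core, so it does not bear directly on the change from compound 3 to compound 4. Nothing measured shows what removing the fluorine and adding a methyl does here. Compound 4 is therefore expected to stay close to compound 3, with a step of a 1.1-fold lower number from compound 3 to compound 4 (0.06 log units; within the scatter) that may well lie within the scatter. Compound 4 is estimated at 150000 nM, between 50000 nM and 450000 nM.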

Compound 4, half-maximal inhibitory concentration: "not active" (no number reported)
No number was reported for compound 4, so the estimate cannot be set against anything.
By their numbers in this assay, from the lowest: compound 2; then compound 1; then compound 3.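

Among the compounds shown here, compound 4 was reported in this assay only as "not active", without a number, so no step from compound 3 to compound 4 can be read. On these data alone, how 2,4-dimethylphenyl in place of 5-fluoro-2-methylphenyl changes the number stays open, and no supporting evidence bears on this result.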